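Phenyl for Ethyl on the Ring Amine: Compound 4

The source may report more compounds than this note shows. Statements on the series, on what has been measured and on what is new or still open speak of the compounds shown alone.

Three compounds have been measured in a functional assay on trachea (Cavia porcellus); a lower number here means a stronger inhibitor, a higher number a weaker inhibitor:

compound 1, `CCCN1CC[C@@]2(OC)OC(N)=C(C#N)[C@@H](c3ccc(Cl)cc3)[C@@H]2C1`, gives 30300 nM
compound 2, `CO[C@@]12CCN(Cc3ccccc3)C[C@H]1[C@H](c1ccc(Cl)cc1)C(C#N)=C(N)O2`, gives 18500 nM
compound 3, `CCCN1CC[C@@]2(OC)OC(N)=C(C#N)[C@@H](c3ccc(F)cc3)[C@@H]2C1`, gives 29600 nM

Compound 4, `CO[C@@]12CCN(Cc3ccccc3)C[C@H]1[C@H](c1ccc(F)cc1)C(C#N)=C(N)O2`, has not yet been measured in this assay.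

Compound 4 differs from compound 3 by phenyl in place of ethyl on a saturated chain carbon bound to an amine nitrogen in a ring. The same change has already been made once among the measured compounds, from compound 1 to compound 2, where it reads phenyl in place of ethyl on a saturated chain carbon bound to an amine nitrogen in a ring and gave a 1.6-fold lower number from compound 1 to compound 2 (0.21 log units; within the scatter). The two cores on which this change is made are not identical: compound 3 differs from compound 1 by fluoro in place of chloro on an aromatic carbon, and that exchange gave a 1.0-fold lower number from compound 1 to compound 3 (0.01 log units; within the scatter). The place of the change is described in the same words for both pairs. The step from compound 3 to compound 4 is thus the same change as the step from compound 1 to compound 2, made on a core that carries fluoro in place of chloro.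

Since the chloro-to-fluoro exchange left the number unchanged within the scatter, as shown by a 1.0-fold lower number from compound 1 to compound 3 (0.01 log units; within the scatter), the step from compound 3 to compound 4 is expected to be of about the size of the earlier phenyl-for-ethyl step, namely a 1.6-fold lower number from compound 3 to compound 4 (0.22 log units; within the scatter). On that basis compound 4 is estimated to give 18000 nM in this assay, with a range from 9000 nM to 36000 nM.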

Compound 4, half-maximal inhibitory concentration: 17200 nM
Estimate against measurement, compound 4: 1.0-fold (0.02 log units) above; measured number inside the range.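

In this assay, the phenyl-for-ethyl change, which can also be read as propyl to benzyl, gives a 1.7-fold lower number from compound 3 to compound 4 (0.24 log units; within the scatter), and this step matches the one made on the chloro-bearing core: the same change on two cores in this assay, a 1.6-fold lower number (0.21 log units; within the scatter) from compound 1 to compound 2 and a 1.7-fold lower number (0.24 log units; within the scatter) from compound 3 to compound 4, 1.1-fold (0.02 log units) apart, within the scatter of two such steps. The fluoro-for-chloro exchange, now seen with the benzyl group on the ring amine, gives a 1.1-fold lower number from compound 2 to compound 4 (0.03 log units; within the scatter), and it too reads alike on both cores: the same change on two cores in this assay, a 1.0-fold lower number (0.01 log units; within the scatter) from compound 1 to compound 3 and a 1.1-fold lower number (0.03 log units; within the scatter) from compound 2 to compound 4, 1.1-fold (0.02 log units) apart, within the scatter of two such steps. This shows that, in these four compounds, each change reads the same on the two cores tested, but every step lies within the scatter, so the agreement is between steps that cannot be told from no change at all, and it does not show that either change has a real effect or that the match would hold on a core differing in more than fluoro for chloro.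

The compounds shown leave open whether any other group on the ring amine, such as a longer chain, a carboxylic acid or a second amine, would move the number beyond the scatter. They also leave open whether a hydrogen or a trifluoromethyl group in place of the fluoro or chloro on the aromatic carbon would do so, and whether the phenyl-for-ethyl step would then read the same.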